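A few compounds are considered here, and "the series" means these few. Any claim that something is new, unique, unknown or untested is made for them only; others in the source may bear on it.

Compound 1 `O=C(CN1CCCCC1)OC1CC2(N3CCCC3)CC(c3ccccc3)C1C(c1ccccc1)C2` sets the reference for this set. In an ADME assay on L6 cells (Rattus norvegicus) for cytotoxicity, read by resazurin assay, with a stated time of 72 h (a higher number here means a weaker inhibitor, a lower number a stronger inhibitor), compound 1 gives 14200 nM, the lowest of the three numbers recorded there. Compound 3 `CN1CCN(CCC(=O)N2CCC3(N4CCCC4)CC(c4ccccc4)C2C(c2ccccc2)C3)CC1` gives 75400 nM in this assay, and compound 2 `CN1CCN(CC(=O)N2CCC3(N(C)C)CC(c4ccccc4)C2C(c2ccccc2)C3)CC1` gives 195000 nM, so both sit well above compound 1, beyond the usual scatter, which leaves compound 1 as the strongest of the three in this assay.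

The next compound, compound 4 `CN1CCN(CCC(=O)NC2CC3(N4CCCC4)CC(c4ccccc4)C2C(c2ccccc2)C3)CC1`, differs from compound 1 in one place: ((2-(4-methylpiperazin-1-yl)ethyl)carbonyl)amino in place of (((piperidin-1-yl)methyl)carbonyl)oxy on a saturated ring carbon. Among the compounds with values here, no measured pair shows exactly this exchange, so its effect has to be judged from the neighbours. Compound 3 already carries the (2-(4-methylpiperazin-1-yl)ethyl)carbonyl group, though attached elsewhere on the core, and its value in this assay lies well above that of compound 1.

Against that background compound 4 is expected to move upward from compound 1, by a step of about a 3.5-fold higher number from compound 1 to compound 4 (0.55 log units; beyond the scatter), with the estimate in this assay placed at 50000 nM and a range from 15000 nM to 160000 nM.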

Compound 4, half-maximal inhibitory concentration: 86700 nM
For compound 4 the middle estimate is 1.7-fold (0.24 log units) below the measured one; the range from low to high includes it.
By their numbers in this assay, from the lowest: compound 1; then compounds 3 and 4 (each within the scatter of the next); then compound 2.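

Within the data shown here, the exchange on this saturated ring carbon gives the first direct reading at this position: in this assay there is a 6.1-fold higher number from compound 1 to compound 4 (0.79 log units; beyond the scatter), so the position does respond to the group it carries. The step changes more than one feature at once, since the oxy link gives way to an amino link with the amide hydrogen, and the piperidin-1-yl ring gives way to a 4-methylpiperazin-1-yl ring on a different chain, so this single pair cannot divide the rise among them. Nothing shown here offers an explanation for the rise.

The compounds shown leave open whether the amino link or the 4-methylpiperazin-1-yl ring carries the step. They also leave open how a free amine or a longer chain ending in a piperidin-1-yl group on this ring carbon would read in this assay.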